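This account rests on a few compounds, and the source may have more. Where it says the series, first, only, none or still open, it means among the compounds named here.

Measured compounds in an assay for inhibition of Fatty-acid amide hydrolase 1 (Rattus norvegicus); a higher number here means a weaker inhibitor, a lower number a stronger inhibitor:
- compound 1, `COC(=O)c1ccc(CCCCCCC(=O)c2ncc(-c3ccccn3)o2)cc1`: 1.5 nM
- compound 2, `O=C(O)c1cccc(CCCCCCC(=O)c2ncc(-c3ccccn3)o2)c1`: only a limit was reached, > 600 nM
- compound 3, `O=C(CCCCCCc1ccc(Cl)cc1)c1ncc(-c2ccccn2)o1`: 2.7 nM

Compound 3 holds the highest of the two numbers, with compound 1 nearest at a 1.8-fold higher number from compound 1 to compound 3 (0.26 log units; within the scatter). Compound 2 sits at a limit of this assay the limit of > 600 nM in this assay, at which 1 of the 3 values shown sits, and gives no number to compare.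

Compound 4, `CN(CCCCCC(=O)c1ncc(-c2ccccn2)o1)c1ccccc1`, has not yet been measured. It differs from compound 3 in one place: methyl(phenyl)amino in place of 4-chlorobenzyl on a saturated chain carbon, five bonds along the chain from a carbonyl carbon. For the measured compounds named here, two measured steps bear on this. The step of a 1.8-fold higher number from compound 1 to compound 3 (0.26 log units; within the scatter) shows that exchanging the group on the aromatic ring at the far end of the chain leaves the number essentially where it was. The step of an at least 220-fold lower number from compound 2 to compound 3 (2.34 log units; beyond the scatter) shows that exchanging the whole group carried on the chain can move the number a great deal. The change to compound 4 keeps a phenyl ring but replaces the benzylic carbon with a methyl(phenyl)amino nitrogen, so the aromatic ring sits one bond nearer the carbonyl. Given that the aromatic ring is retained, a step nearer the scatter than the one from compound 2 to compound 3 is expected, with some risk of weakening. Compound 4 is therefore expected to give 6 nM, ranging from 1.5 nM to 40 nM, i.e. an expected step of a 2.2-fold higher number from compound 3 to compound 4 (0.35 log units; beyond the scatter).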

Compound 4, inhibition constant: 40 nM
Beside the measured number, compound 4's estimate is 6.7-fold (0.82 log units) below it; low and high end bracket the measured number.
By their numbers in this assay, from the lowest: compounds 1 and 3 (each within the scatter of the next); then compound 4. At a limit, above all of these: compound 2.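

In this assay, methyl(phenyl)amino in place of 4-chlorobenzyl on a saturated chain carbon, five bonds along the chain from a carbonyl carbon, gives a 15-fold higher number from compound 3 to compound 4 (1.17 log units; beyond the scatter). The earlier exchange of chloro and methoxycarbonyl on the aromatic carbon stayed within the scatter, whereas this one is large even though both the group that leaves and the group that enters have 8 heavy atoms and one six-membered aromatic ring of carbon only, so keeping such a ring on the chain does not by itself hold the number at this position. The exchange removes the chlorine and brings in a nitrogen with 1 hydrogen-bond acceptor, but no measurement shown gives a reason for the step.

The compounds shown leave open whether the step follows the loss of the chlorine, the entry of the nitrogen or the different attachment of the ring. An unsubstituted benzyl group, a phenylamino group without the methyl, and a longer chain carrying methyl(phenyl)amino would each separate part of this exchange.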